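The source may hold more compounds than are shown below. What is called first, only, known or untested is meant among the compounds shown, and "the series" means these compounds.

Compound 1 `COc1ccccc1C1C(C#N)=C(N)N(c2cc(OC)c(OC)c(OC)c2)C2=C1C(=O)CC(C)(C)C2` has the highest of the three numbers in a functional assay on Ehrlich cells (Mus musculus) for cytotoxicity, tested at 100 ug/mL (a higher number here means a stronger effect of the compound at the concentration tested, a lower number a weaker effect), giving 100%, though compound 2 `COc1cc(N2C(N)=C(C#N)C(c3ccc(C)cc3)C3=C2CC(C)(C)CC3=O)cc(OC)c1OC` with 90% lies within the scatter of it, the step being a number 10 percentage points lower from compound 1 to compound 2 (within the scatter). Compound 3 `COc1cc(N2C(N)=C(C#N)C(c3c(OC)ccc4ccccc34)C3=C2CC(C)(C)CC3=O)cc(OC)c1OC` stands furthest away with 30%, the step being a number 70 percentage points lower from compound 1 to compound 3 (beyond the scatter). Compound 4 `COc1ccc(C2C(C#N)=C(N)N(c3cc(OC)c(OC)c(OC)c3)C3=C2C(=O)CC(C)(C)C3)cc1` differs from compound 1 in a single place: 4-methoxyphenyl in place of 2-methoxyphenyl on a saturated ring carbon. The step that bears on this most is a number 10 percentage points lower from compound 1 to compound 2 (within the scatter), where 2-methoxyphenyl likewise gave way to a 4-substituted phenyl, 4-methylphenyl, without a change beyond the scatter; the large fall in a number 70 percentage points lower from compound 1 to compound 3 (beyond the scatter) belongs to 2-methoxynaphthalen-1-yl and is less relevant. The expected step is therefore a number 10 percentage points lower from compound 1 to compound 4 (within the scatter), none beyond the scatter. Compound 4 is estimated at 90%, between 70% and 100%.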

Compound 4, a percentage reported as activity, at one concentration (the size of the read-out at that concentration, not a potency): 15%
Beside the measured number, compound 4's estimate is 75 percentage points above it; measured number below the stated range.
By their numbers in this assay, from the lowest: compound 4; then compound 3; then compounds 2 and 1 (each within the scatter of the next).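

With the same atoms present, moving the methoxy group from 2-methoxyphenyl to 4-methoxyphenyl gives a number 85 percentage points lower from compound 1 to compound 4 (beyond the scatter) in this assay, so the result at this saturated ring carbon depends on where the methoxy group sits on the phenyl ring. A 4-substituted phenyl is not enough to keep the effect, since methoxy in place of methyl gives a number 75 percentage points lower from compound 2 to compound 4 (beyond the scatter) on the same ring. Even the 2-methoxynaphthalen-1-yl group keeps more of the effect, with a number 15 percentage points lower from compound 3 to compound 4 (beyond the scatter) as the step.

No evidence at hand accounts for these falls. Going by these compounds, whether a hydroxy group, a chlorine or a dimethylamino group on this phenyl ring would follow methyl or methoxy remains open.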